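Replacing the 3-hydroxyazetidin-1-yl group on the shared core

The source may hold more compounds than are shown below. What is called first, only, known or untested is meant among the compounds shown, and "the series" means these compounds.

In a physicochemical assay for solubility, in phosphate buffer, with a stated time of 2 h (on this read-out lower numbers stand for lower solubility and higher numbers for higher solubility), compound 1 (`Cc1nc(-c2ccc(-c3ccccc3)cc2)sc1-c1ccnc(NC(=N)N)n1`) gives 2200 nM and compound 2 (`Cc1nc(-c2ccc(-c3ccccc3)cc2)sc1-c1nnc(N2CC(O)C2)o1`) gives 150000 nM on the same scale. Compound 2 holds the higher of the two numbers, and its gap to compound 1 lies beyond the scatter. Among the compounds with values here, these two compounds differ in more than one place, so the series offers no measured single-change step.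

Compound 3 (`Cc1nc(-c2ccc(-c3ccccc3)cc2)sc1-c1nnc(NC(=N)N2CCN(C)CC2)o1`) has not yet been measured. The change from compound 2 is a group of 10 heavy atoms (6 carbon, 4 nitrogen; one six-membered non-aromatic ring with 2 hetero atoms) in place of a group of 5 heavy atoms (3 carbon, 1 nitrogen, 1 oxygen; one four-membered non-aromatic ring with 1 hetero atom), on an aromatic carbon. The entering group has a double bond outside aromatic rings. Of the two measured compounds, only compound 1 shares this feature, and compound 1 stands at 2200 nM in this assay. This is thin support, but a move downward, beyond the scatter, is expected. The estimated step of a 7.5-fold lower number from compound 2 to compound 3 (0.88 log units; beyond the scatter) stops short of reaching that lower number. For compound 3 the expected value is 20000 nM, with an estimated range from 4000 nM to 100000 nM.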

Compound 3, solubility: 104000 nM
Compound 3: middle estimate off by 5.2-fold (0.72 log units), on the low side; the measured number lies above the stated range.
By their numbers in this assay, from the lowest: compound 1; then compounds 3 and 2 (each within the scatter of the next).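

Within the data shown here, this is the first single-change step: in this assay, replacing the 3-hydroxyazetidin-1-yl group on the aromatic carbon of the five-membered aromatic ring gives a 1.4-fold lower number from compound 2 to compound 3 (0.16 log units; within the scatter). The two compounds cannot be told apart on this read-out, even though the entering group has 10 heavy atoms against 5, a six-membered non-aromatic ring in place of a four-membered one, and a double bond outside aromatic rings. No measured evidence on why these numbers stand as they do bears on this result.

From the compounds shown here alone, whether an open-chain dimethylamino group or a carboxylic acid on the same aromatic carbon would also stay within the scatter of compound 2 remains open, and one step cannot show how far this position tolerates change. Among these compounds, compound 1 differs from compound 2 and from compound 3 in more than one place, so it gives no measured step for this position, and the contribution of each part of the entering group also remains unresolved.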